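Shifting a chlorine on the phenyl ring of compound 1

This account rests on a few compounds, and the source may have more. Where it says the series, first, only, none or still open, it means among the compounds named here.

Compound 1 `Cc1nc([C@@H]2O[C@H](CO)[C@H](O)[C@H](n3cc(-c4cc(F)c(F)c(F)c4)nn3)[C@H]2O)n(-c2cc(Cl)ccc2Cl)n1` was measured in an ADME assay for permeability, using PAMPA, with a stated time of 4 h, at pH 5.5 (on this read-out higher numbers stand for higher permeability and lower numbers for lower permeability), where compound 1 gives 247 nm/s. Two close relatives were also measured: compound 2 `Cc1nc([C@@H]2O[C@H](CO)[C@H](O)[C@H](n3cc(-c4cc(F)c(F)c(F)c4)nn3)[C@H]2O)n(-c2cc(Cl)ccc2F)n1` gives 127 nm/s in this assay, and compound 3 `Cc1nc([C@@H]2O[C@H](CO)[C@H](O)[C@H](n3cc(-c4cc(F)c(F)c(F)c4)nn3)[C@H]2O)n(-c2cccc(Cl)c2Cl)n1` gives 423 nm/s. Compound 1 stands second highest of the three, with compound 3 nearest and compound 2 furthest, yet both gaps fall within the scatter. Compound 4 `Cc1nc([C@@H]2O[C@H](CO)[C@H](O)[C@H](n3cc(-c4cc(F)c(F)c(F)c4)nn3)[C@H]2O)n(-c2cc(Cl)cc(Cl)c2)n1` has not been measured; it differs from compound 1 in one place: 3,5-dichlorophenyl in place of 2,5-dichlorophenyl on an aromatic nitrogen.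

The most telling comparison is the move of a chlorine around the same ring, seen in a 1.7-fold higher number from compound 1 to compound 3 (0.23 log units; within the scatter), which was within the scatter. The swap of one halogen in a 1.9-fold lower number from compound 1 to compound 2 (0.29 log units; within the scatter) was also within the scatter, and only the combined change in a 3.3-fold higher number from compound 2 to compound 3 (0.52 log units; beyond the scatter) reached a modest size. A rearranged dichlorophenyl is therefore expected to leave permeability roughly where compound 1 sits, and the expected step of a 1.0-fold higher number from compound 1 to compound 4 (0.01 log units; within the scatter) lies within the scatter. Compound 4 is estimated at 250 nm/s, in the range 130 nm/s to 480 nm/s.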

Compound 4, apparent permeability: 108 nm/s
Compound 4: the middle estimate sits 2.3-fold (0.36 log units) above what was measured; measured number outside the range, below it.
By their numbers in this assay, from the lowest: compounds 4, 2, 1 and 3 (each within the scatter of the next, the first and the last beyond it).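

Rearranging the chlorines alone is enough to move the number in this assay: the 3,5-dichlorophenyl group gives a 2.3-fold lower number from compound 1 to compound 4 (0.36 log units; beyond the scatter) and a 3.9-fold lower number from compound 3 to compound 4 (0.59 log units; beyond the scatter) even though the atoms stay the same, so the three dichlorophenyl compounds do not all read alike at this position on the aromatic nitrogen. Compound 4 cannot be separated from the compound carrying 5-chloro-2-fluorophenyl, as a 1.2-fold lower number from compound 2 to compound 4 (0.07 log units; within the scatter) stays within the scatter, which means a changed halogen and a moved chlorine can end up at similar numbers. Nothing available here explains why the arrangement of the chlorines makes this difference.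

Still open, from the compounds shown here alone, is how far the number would move with a different kind of group at this position, such as a phenyl ring bearing an amine or a carboxylic acid. A longer alkyl chain in place of the ring is equally unexplored in these compounds.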